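The source may report more compounds than this note shows. Statements on the series, on what has been measured and on what is new or still open speak of the compounds shown alone.

Compound 1 `Fc1ccc(-c2nn3c(NC4CCCC4)cc(NC4CCCC4)cc3c2-c2ccnc(NC3CCCC3)n2)cc1` gives > 40000 nM in an ADME assay on Vero cells (Chlorocebus sabaeus) for cytotoxicity (on this read-out lower numbers stand for higher toxicity in this test and higher numbers for lower toxicity in this test), a value that is a limit of the assay.
Compound 2 `COc1ccc(-c2nn3c(Cl)cc(Cl)cc3c2-c2ccnc(NC3CCCC3)n2)cc1` gives > 40000 nM in this assay, again a limit.
Compound 3 `COc1ccc(-c2nn3c(NC4CCCC4)cc(Cl)cc3c2-c2ccnc(NC3CCCC3)n2)cc1` gives > 40000 nM in this assay, also a limit.

Going by the values given here, the one step measured here, from compound 3 to compound 2, is a step that the two limits leave unreadable from compound 3 to compound 2; the change behind it is chloro in place of cyclopentylamino on an aromatic carbon. The two cores of compound 1 and compound 3 differ in more than one place, and that difference is not broken down here. Compound 4 `Fc1ccc(-c2nn3c(Cl)cc(NC4CCCC4)cc3c2-c2ccnc(NC3CCCC3)n2)cc1` has not yet been tested. It differs from compound 1 by chloro in place of cyclopentylamino on an aromatic carbon, the same kind of change as from compound 3 to compound 2, but here the place is meta to a cyclopentylamino group rather than meta to a chloro group. Since (the limit of > 40000 nM in this assay, at which 3 of the 3 values shown sit), the step from compound 1 to compound 4 is expected to be about a step that the limit leaves unreadable from compound 1 to compound 4, which is no more than a guess that the limit will be reached again. Compound 4 is therefore estimated at 50000 nM, with a plausible range from 25000 nM to 120000 nM.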

Compound 4, half-maximal cytotoxic concentration: > 40000 nM
Compound 4 ended at the assay's limit; the forecaster's own chance of this, stated with the estimate: 85%; the middle value is on the limit's open side.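

Compound 1 and compound 4 both stand at a limit of this assay, so no step can be read between them, and the change from cyclopentylamino to chloro shows no size: the limit of > 40000 nM in this assay, at which 4 of the 4 values shown sit. Still open, as far as these compounds go, is at what concentration these four compounds would harm the cells, and whether that change alters it at all.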